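The compounds below may be only part of what the source reports. "The series", "measured", "known", "first", "only" and "open" are said of these compounds alone.

Measured compounds in the series:

Compound 1, `C=C(CC)C(=O)c1ccc(OCC(=O)Nc2ccc(C(N)=O)cc2)c(Cl)c1Cl` — in a functional assay on CLL cells (Homo sapiens) for cytotoxicity, read by MTT assay, with a stated time of 48 h (a lower number here means that less compound is needed, a higher number that more compound is needed for the effect), compound 1 gives 3700 nM.
Compound 2, `C=C(CC)C(=O)c1ccc(OCC(=O)NCC(=O)O)c(Cl)c1Cl` — in this assay compound 2 gives only a limit, > 25000 nM.

Compound 2 thus sits at the upper limit of the assay, (the limit of > 25000 nM in this assay, at which 1 of the 2 values shown sits), and no number is known for it; it stands no better than this ceiling on the numbers shown. Within the data shown here, the one step measured so far is an at least 6.7-fold higher number from compound 1 to compound 2 (0.82 log units; beyond the scatter), so swapping the 4-carbamoylphenyl for a small carboxymethyl weakened the compound well beyond the scatter.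

Compound 3, `C=C(CC)C(=O)c1ccc(OCC(=O)NCC2CCC(C(=O)O)CC2)c(Cl)c1Cl`, is the next point on this path. Relative to compound 2 the change is 4-carboxycyclohexyl in place of carboxy on a saturated chain carbon bound to an amide-type nitrogen. It keeps the carboxylic acid of compound 2 but brings back a six-membered ring, with more carbon, in the region where compound 1 carried its aryl amide. Among the measured compounds shown here, the measured step of an at least 6.7-fold higher number from compound 1 to compound 2 (0.82 log units; beyond the scatter) is the only guide, and it argues that the ring-bearing side chain is the more favourable arrangement in this assay, while the acid remains present. Some recovery toward compound 1 is expected, but not a full one, and it may still sit at the limit. Compound 3 is estimated at 15000 nM, range 5000 nM to 40000 nM, which corresponds to an expected step of an at least 1.6-fold lower number from compound 2 to compound 3 (0.22 log units; that floor lies within the scatter).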

Compound 3, half-maximal effective concentration: 8000 nM
Compound 3: middle estimate off by 1.9-fold (0.27 log units), on the high side, and the stated range covers the measured number.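

In this assay, placing 4-carboxycyclohexyl in place of carboxy on a saturated chain carbon bound to an amide-type nitrogen gives an at least 3.1-fold lower number from compound 2 to compound 3 (0.49 log units; beyond the scatter). This shows that a carboxylic acid on this side chain does not by itself keep a compound at the limit, since compound 3 retains the acid and still gives a measured number. The size of this change remains only a floor, because compound 2 has a limit and not a number: the limit of > 25000 nM in this assay, at which 1 of the 3 values shown sits.

As far as these compounds go, compound 1 gives 3700 nM and compound 3 gives 8000 nM, but their side chains differ in both the ring and the terminal group, so the separate contributions of the six-membered ring and the carboxylic acid remain open. A cyclohexyl side chain ending in a primary carboxamide or a methyl ester, or a phenyl ring carrying a carboxylic acid, would separate these contributions, and a longer chain between the amide nitrogen and the ring would test whether the distance to the ring matters.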